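Tellurium for selenium on the side chain of compound 3

This account rests on a few compounds, and the source may have more. Where it says the series, first, only, none or still open, it means among the compounds named here.

Measured in an ADME assay on cells (Fibroblast, Homo sapiens) for cytotoxicity, read by MTT assay, with a stated time of 24 h; on this read-out lower numbers stand for stronger inhibition and higher numbers for weaker inhibition:
compound 1 `COc1ccc(N(CC(=O)NCCCSc2ccccc2)C(=O)CCSC2=C(C)C(=O)c3ccccc3C2=O)cc1` — 26000 nM
compound 2 `O=C(COC(=O)/C=C/c1ccccc1)NCCC[Te]c1ccccc1` — 11000 nM
compound 3 `COc1ccc(N(CC(=O)NCCC[Se]c2ccccc2)C(=O)CCSC2=C(C)C(=O)c3ccccc3C2=O)cc1` — 24000 nM

Compound 3 and compound 1 lie within the scatter of each other in this assay; compound 2, built on a different scaffold, gives a number beyond the scatter below that of compound 3, so compound 3 stands toward the weaker-inhibition end of the three.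

Compound 4 `COc1ccc(N(CC(=O)NCCC[Te]c2ccccc2)C(=O)CCSC2=C(C)C(=O)c3ccccc3C2=O)cc1` has not been measured. It differs from compound 3 by a group of 7 heavy atoms (6 carbon, 1 tellurium; one six-membered aromatic ring of carbon only) in place of a group of 7 heavy atoms (6 carbon, 1 selenium; one six-membered aromatic ring of carbon only), on a saturated chain carbon, three bonds along the chain from an amide-type nitrogen. Going by the values given here, the one measured step of this kind, a 1.1-fold lower number from compound 1 to compound 3 (0.03 log units; within the scatter), exchanged sulfur for selenium at the same place and moved nothing beyond the scatter. Among the compounds with values here, no measured step exchanges selenium for tellurium on the shared core; compound 2 carries tellurium but on another scaffold, and its value and that of compound 3 cannot be read as a step. On this basis the expectation for compound 4 is a small change at most, a 1.3-fold lower number from compound 3 to compound 4 (0.12 log units; within the scatter), with wide uncertainty. The estimated value for compound 4 is 18000 nM, with a range of 8000 nM to 40000 nM.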

Compound 4, half-maximal inhibitory concentration: 4000 nM
Beside the measured number, compound 4's estimate is 4.5-fold (0.65 log units) above it, and the stated range ends above it.
By their numbers in this assay, from the lowest: compound 4; then compound 2; then compounds 3 and 1 (each within the scatter of the next).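

In this assay, the group with tellurium on the saturated chain carbon, three bonds along the chain from an amide-type nitrogen, gives a step beyond the scatter against the selenium group (a 6.0-fold lower number from compound 3 to compound 4 (0.78 log units; beyond the scatter)) and against the sulfur group (a 6.5-fold lower number from compound 1 to compound 4 (0.81 log units; beyond the scatter)). The position therefore responds to the exchange of this one atom, although the sulfur-to-selenium step (a 1.1-fold lower number from compound 1 to compound 3 (0.03 log units; within the scatter)) lies within the scatter; on the shared core, the shift beyond the scatter appears only with tellurium. Nothing shown here accounts for this difference.

From the compounds shown here alone, it remains open whether the step persists with a methyl group in place of the aromatic ring on tellurium, or with a longer chain. Compound 2 carries tellurium on another scaffold, so whether the step carries over to a different core also stays unresolved.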